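Phenyl in place of isopentyl: what to expect

The source may hold more compounds than are shown below. What is called first, only, known or untested is meant among the compounds shown, and "the series" means these compounds.

Compound 1 `CC(C)CN(C)Cc1ccc(C2=CCCN(C)C2)cc1` and compound 2 `CC(C)CCN(C)Cc1ccc(C2=CCCN(C)C2)cc1` and compound 3 `CC(C)CCCN(C)Cc1ccc(C2=CCCN(C)C2)cc1` share one core. In an ADME assay on HL-60 cells (Homo sapiens) for cytotoxicity, read by MTT assay, with a stated time of 24 h (on this read-out higher numbers stand for weaker inhibition and lower numbers for stronger inhibition), compound 1 gives > 50000 nM as a limit and not a number. Compound 2 gives > 50000 nM which is likewise a limit. Compound 3 gives > 50000 nM as a limit too, so no number places it. Compound 4 `CN1CCC=C(c2ccc(CN(C)Cc3ccccc3)cc2)C1` has phenyl in place of isopentyl on a saturated chain carbon bound to an amine nitrogen, counted as phenyl in place of isopentyl on a saturated chain carbon bound to an amine nitrogen in full. The steps bearing on this are a step that the two limits leave unreadable from compound 1 to compound 3 and a step that the two limits leave unreadable from compound 2 to compound 3 and neither has a size to carry over. No clear direction is therefore expected, and the estimated change is a number no higher from compound 3 to compound 4 (the limit leaves the size open) at most modest. Compound 4 is estimated at 50000 nM (range 20000 nM to 100000 nM) and may well return only a limit.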

Compound 4, half-maximal inhibitory concentration: > 50000 nM
Compound 4: a limit, no number; the forecaster's own chance of this, stated with the estimate: 75%; the middle value lies on the limit itself.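

Compound 4 gives only a limit, like compound 1, compound 2 and compound 3, so no step between them can be read in this assay: the limit of > 50000 nM in this assay, at which 4 of the 4 values shown sit.

On these data alone, whether swapping these groups changes the cytotoxicity at all remains open.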